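This account rests on a few compounds, and the source may have more. Where it says the series, first, only, none or still open, it means among the compounds named here.

Compound 1 `c1ccc(COc2ccc(OCCOCCNc3ccccc3)cc2)cc1` stands at the edge of what a functional assay on SK-OV-3 cells (Homo sapiens) for inhibition, read by CCK-8 assay, with a stated time of 70 h (a higher number here means a weaker inhibitor, a lower number a stronger inhibitor), can report: in this assay compound 1 gives > 100000 nM, which is a limit and not a number. Compound 3 `O=C(O)c1ccc(COc2ccc(OCCOCCNC3CCCC3)cc2)cc1` likewise gives only a limit in this assay, > 100000 nM. Among the compounds with values here, compound 2 `c1ccc(COc2ccc(COc3ccc(OCCOCCNC4CCCC4)cc3)cc2)cc1` is the one member of the set with a measured number, 10000 nM in this assay. Within the data shown here, the only step measured within the set is an at least 10-fold higher number from compound 2 to compound 3 (1.00 log units; beyond the scatter), and it sits on the outer aromatic ring, not on the amine nitrogen. The wider picture is given by the limit of > 100000 nM in this assay, at which 2 of the 3 values shown sit, so most of the set is unresolved.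

Compound 4 `c1ccc(COc2ccc(OCCOCCNC3CCCCCC3)cc2)cc1` follows from compound 1 by cycloheptyl in place of phenyl on an amine nitrogen. Among the measured compounds shown here, no measured step touches the amine nitrogen, so nothing sets the size of this change directly. For the measured compounds named here, compound 2 carries a saturated ring on that nitrogen and is the only compound with a number, but it also differs from compound 4 at the far end of the chain. For that reason the value of compound 2, 10000 nM, is only a loose guide. The expectation is that compound 4 moves off the limit by an at least 3.3-fold lower number from compound 1 to compound 4 (0.52 log units; beyond the scatter), with a real chance that this assay again reports only a limit. Compound 4 is therefore estimated at 30000 nM, within 8000 nM to 100000 nM.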

Compound 4, half-maximal inhibitory concentration: 7460 nM
Compound 4: middle estimate off by 4.0-fold (0.60 log units), on the high side, outside the stated range (below it).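

Within the data shown here, on the amine nitrogen, cycloheptyl in place of phenyl gives the only measured step at this position in this assay: an at least 13-fold lower number from compound 1 to compound 4 (1.12 log units; beyond the scatter). The step lies beyond the scatter and is open-ended, since the compound 1 end of it is a limit, so the true change may be larger than printed. Among these compounds, in this one pair, the group on the amine nitrogen decides whether the assay returns a number at all: with phenyl there it gives only a limit, and with cycloheptyl it gives a measured value, so this position matters at least as much as the outer aromatic ring, where the only other step sits.

A single pair cannot separate the loss of the aromatic ring from the size of the saturated ring, and a cyclohexyl group, an open-chain butyl group or a benzyl group on the same nitrogen would be needed to tell these apart. Whether the change carries over to other ends of the chain also stays unsettled, and much of the set remains unresolved: the limit of > 100000 nM in this assay, at which 2 of the 4 values shown sit.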